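Same Ring Swap, Tried Again on a Rearranged Core

A few compounds are considered here, and "the series" means these few. Any claim that something is new, unique, unknown or untested is made for them only; others in the source may bear on it.

Compound 1, `COc1ccc(OC)c(/C=C/C(=O)C(=Cc2cc(OC)c(O)c(OC)c2)C(=O)/C=C/c2cc(OC)ccc2OC)c1`, gives 190 nM in a functional assay on A549 cells (Homo sapiens) for antiproliferative activity, read by sulforhodamine B assay, with a stated time of 48 h; a higher number here means a weaker inhibitor, a lower number a stronger inhibitor.
Compound 2, `COc1ccc(OC)c(/C=C/C(=O)C(=Cc2ccc(OC)c(O)c2)C(=O)/C=C/c2cc(OC)ccc2OC)c1`, gives 390 nM in this assay.
Compound 3, `COc1ccc(/C=C/C(=O)C(=Cc2cc(OC)c(O)c(OC)c2)C(=O)/C=C/c2ccc(OC)cc2OC)c(OC)c1`, gives 300 nM in this assay.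

Compound 1 and compound 2 share one core, and the change between them is 3-hydroxy-4-methoxyphenyl in place of 4-hydroxy-3,5-dimethoxyphenyl on a double-bonded chain carbon bound to a double-bonded chain carbon. That change produced a 2.1-fold higher number from compound 1 to compound 2 (0.31 log units; beyond the scatter). Compound 3 is built from the same atoms as compound 1, joined differently; the difference between the two cores is not broken down here. Compound 4, `COc1ccc(/C=C/C(=O)C(=Cc2ccc(OC)c(O)c2)C(=O)/C=C/c2ccc(OC)cc2OC)c(OC)c1`, has not yet been measured. It stands to compound 3 as compound 2 stands to compound 1, the change being (3-hydroxy-4-methoxyphenyl in place of 4-hydroxy-3,5-dimethoxyphenyl on a double-bonded chain carbon bound to a double-bonded chain carbon), the same change on the same place. Because the earlier instance gave a 2.1-fold higher number from compound 1 to compound 2 (0.31 log units; beyond the scatter), the step from compound 3 to compound 4 is expected to be a 2.0-fold higher number from compound 3 to compound 4 (0.30 log units; within the scatter), with added uncertainty since the change has been seen only once and on a different core. Compound 4 is therefore expected to give about 600 nM, somewhere between 330 nM and 1100 nM.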

Compound 4, half-maximal inhibitory concentration: 380 nM
Estimate against measurement, compound 4: 1.6-fold (0.20 log units) above; the measured number falls inside the stated range.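

In this assay, the same ring swap on the second core gives a 1.3-fold higher number from compound 3 to compound 4 (0.10 log units; within the scatter), a step too small on its own to tell from no change at all. Set beside the step on the first core, it does not differ by more than the scatter, so the swap's effect looks consistent across these two cores: the same change on two cores in this assay, a 2.1-fold higher number (0.31 log units; beyond the scatter) from compound 1 to compound 2 and a 1.3-fold higher number (0.10 log units; within the scatter) from compound 3 to compound 4, 1.6-fold (0.21 log units) apart, within the scatter of two such steps

For the compounds shown here, this does not show that the effect has one fixed size, since there are only two cores and only the step on the first core lies beyond the scatter.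

The rings swapped here carry only hydroxy and methoxy groups. Going by these compounds, what an amine or a carboxylic acid at that place would do remains open.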